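Adding Fluorine to the Fused Ring System

The source may hold more compounds than are shown below. What is called first, only, known or untested is meant among the compounds shown, and "the series" means these compounds.

For the measured compounds named here, compound 1 `Fc1cc(Cl)ccc1-c1ccc(Cn2nnc3ccccc32)cn1` is one of two compounds measured in an ADME assay on microsomes from liver (Mus musculus, strain NMRI) for metabolic stability, tested at 2.5 uM (on this read-out lower numbers stand for slow clearance and higher numbers for fast clearance), where compound 1 gives 3.4 mL/min/g. It stands alongside compound 2 `Clc1ccc(-c2ccc(Cn3nnc4ccccc43)cn2)cc1`, which gives 3.8 mL/min/g in this assay; the step of a 1.1-fold higher number from compound 1 to compound 2 (0.05 log units; within the scatter) lies within the scatter, so the two numbers cannot be told apart. Compound 3 `Fc1ccc2nnn(Cc3ccc(-c4ccc(Cl)cc4F)nc3)c2c1` has not yet been measured. It differs from compound 1 in one place: fluoro in place of hydrogen on an aromatic carbon. Going by the values given here, the only measured step, from compound 1 to compound 2, also swaps hydrogen for fluoro on an aromatic carbon, though on another part of the shared core, and it stayed within the scatter. On that basis no step beyond the scatter is expected, and no change at the digits printed from compound 1 to compound 3 (within the scatter) is the estimated change. The estimate for compound 3 in this assay is therefore 3.4 mL/min/g, expected to fall between 2 mL/min/g and 6 mL/min/g.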

Compound 3, intrinsic clearance in a liver preparation (reported as CLH), per the amount of preparation that the assay uses: 2.2 mL/min/g
Compound 3: the middle estimate sits 1.5-fold (0.19 log units) above what was measured; measured number inside the range.
By their numbers in this assay, from the lowest: compounds 3, 1 and 2 (each within the scatter of the next).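

Read in this assay a fluoro on an aromatic carbon of the six-membered ring of carbon only, part of the fused system of two rings, gives a 1.5-fold lower number from compound 1 to compound 3 (0.19 log units; within the scatter) and so stays inside the usual spread of repeat measurements. For the compounds shown here, this is the first look at a change on this ring, since the earlier step, a 1.1-fold higher number from compound 1 to compound 2 (0.05 log units; within the scatter) and also within the scatter, lay on another part of the shared core. No measurement shown here offers an explanation for the number.

Still open, as far as these compounds go, is whether a larger group on this same carbon, such as methoxy or an amine, would carry the clearance beyond the scatter. Also open, from the compounds shown here alone, is whether a fluoro on the other carbons of this ring would read the same.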